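The source may report more compounds than this note shows. Statements on the series, on what has been measured and on what is new or still open speak of the compounds shown alone.

In a functional assay on A549 cells (Homo sapiens) for antiproliferative activity, read by MTT assay, with a stated time of 48 h (a higher number here means a weaker inhibitor, a lower number a stronger inhibitor), compound 1 `C/C(=C\CC/C(C)=C/CC[C@@H]1[C@@]2(C)CCC(=O)C(C)(C)[C@H]2CC[C@@]1(C)O)CC/C=C(\C)C(=O)OCc1cn(-c2ccc([N+](=O)[O-])cc2)nn1` gives > 150000 nM, which is a limit of the assay. Compound 2 `C/C(=C\CC/C(C)=C/CC[C@@H]1[C@@]2(C)CCC(=O)C(C)(C)[C@H]2CC[C@@]1(C)O)CC/C=C(\C)C(=O)OCc1cn(-c2cccc(C)c2)nn1` gives > 150000 nM, also a limit. Going by the values given here, compound 3 `C/C(=C\CC/C(C)=C/CC[C@@H]1[C@@]2(C)CCC(=O)C(C)(C)[C@H]2CC[C@@]1(C)O)CC/C=C(\C)C(=O)OCc1cn(-c2cccc(F)c2)nn1` gives 124000 nM, the only actual number among the three. Compound 4 `C/C(=C\CC/C(C)=C/CC[C@@H]1[C@@]2(C)CCC(=O)C(C)(C)[C@H]2CC[C@@]1(C)O)CC/C=C(\C)C(=O)OCc1cn(-c2ccc(Cl)cc2)nn1` differs from compound 3 in one place (4-chlorophenyl in place of 3-fluorophenyl on an aromatic nitrogen), with 4-chlorophenyl in place of 3-fluorophenyl on an aromatic nitrogen. Among the compounds with values here, two measured steps bear on this change of the group on that nitrogen or its ring: an at least 1.2-fold lower number from compound 1 to compound 3 (0.08 log units; that floor lies within the scatter) and an at least 1.2-fold lower number from compound 2 to compound 3 (0.08 log units; that floor lies within the scatter). Each gives only a floor, so no step beyond the scatter is expected in this assay. The expected change is a 1.0-fold higher number from compound 3 to compound 4 (0.02 log units; within the scatter). For compound 4 the estimated value is 130000 nM, with an expected range of 70000 nM to 220000 nM.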

Compound 4, half-maximal inhibitory concentration: > 150000 nM
Compound 4 ended at the assay's limit; the forecaster's own chance of this, stated with the estimate: 45%; middle value at least 1.1-fold (0.06 log units) from the limit.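

With 4-chlorophenyl in place of 3-fluorophenyl, this assay shows an at least 1.2-fold higher number from compound 3 to compound 4 (0.08 log units; that floor lies within the scatter). The steps from compound 1 and from compound 2 to compound 4 cannot be read. A halogen on the phenyl ring therefore does not by itself give a number, and compound 3 remains the only compound that does, with the others sitting at one ceiling: the limit of > 150000 nM in this assay, at which 3 of the 4 values shown sit.

Whether any group on this nitrogen can bring the series well inside the readable range stays open, as the compounds shown carry only substituted phenyl rings there. An amine on that phenyl ring, or a longer chain in its place, would bear on this.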